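Swapping the Aryl Halide Ring: a Cytotoxicity Outlook

A few compounds are considered here, and "the series" means these few. Any claim that something is new, unique, unknown or untested is made for them only; others in the source may bear on it.

Measured compounds:
compound 1, `O=C(COc1cccc2ccccc12)N/N=C/c1ccccc1Br`, 11.4 ug/mL
compound 2, `COc1ccc(/C=N/NC(=O)COc2cccc3ccccc23)cc1OC`, 14.7 ug/mL
compound 3, `COc1ccc(OC)c(/C=N/NC(=O)COc2cccc3ccccc23)c1`, 19.3 ug/mL

In an ADME assay on MT4 cells (Homo sapiens) for cytotoxicity, read by MTT assay, with a stated time of 4 days (on this read-out higher numbers stand for lower toxicity in this test and lower numbers for higher toxicity in this test), compound 1 gives the lowest of the three numbers, yet its gaps to compound 2 and to compound 3 both fall within the usual scatter, so the three compounds cannot be told apart on this read-out. All three share the same core and differ only in the aromatic ring hanging from the carbon with a double bond to nitrogen.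

Compound 4, `O=C(COc1cccc2ccccc12)N/N=C/c1ccc(F)cc1`, has not yet been measured. It differs from compound 1 in one place: 4-fluorophenyl in place of 2-bromophenyl on a carbon with a double bond to nitrogen. Among the measured compounds shown here, no pair of measured compounds shows what such a ring swap does here; the only evidence is that three different rings at this position gave numbers within the scatter of one another.

On that basis the step of a 1.2-fold higher number from compound 1 to compound 4 (0.09 log units; within the scatter) is expected to be small, with no direction beyond the scatter. For compound 4 the expected value in this assay is 14 ug/mL, within a range from 6 ug/mL to 35 ug/mL.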

Compound 4, half-maximal cytotoxic concentration: 65.1 ug/mL
Estimate against measurement, compound 4: 4.7-fold (0.67 log units) below, outside the stated range (above it).
By their numbers in this assay, from the lowest: compounds 1, 2 and 3 (each within the scatter of the next); then compound 4.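

In this assay the ring on the carbon with a double bond to nitrogen proves able to move the read-out: 4-fluorophenyl in place of 2-bromophenyl gives a 5.7-fold higher number from compound 1 to compound 4 (0.76 log units; beyond the scatter), which means lower toxicity to the cells in this test. The earlier compounds shown here offered no step between compounds differing in one place, and their numbers lay within the scatter of one another, so they gave no sign that a change of ring here could matter this much. Nothing measured here accounts for the rise.

This single swap changes both the halogen and its place on the ring, and one pair cannot separate the two. Also open, on these data alone, is what a phenyl ring carrying an amine or a carboxylic acid instead of a halogen would give here.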